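Acid and ester chain variants on a shared core

This account rests on a few compounds, and the source may have more. Where it says the series, first, only, none or still open, it means among the compounds named here.

Measured values in an assay (Cricetulus griseus) for inhibition of Monoamine oxidase (Homo sapiens); on this read-out lower numbers stand for stronger inhibition and higher numbers for weaker inhibition:
compound 1 `O=C(O)CCCCOc1ccc2c(=O)c(-c3ccc(O)cc3)coc2c1`: 5000 nM
compound 2 `CCOC(=O)CCCCCOc1ccc2c(=O)c(-c3ccc(O)cc3)coc2c1`: 5300 nM
compound 3 `CCOC(=O)CCCCOc1ccc2c(=O)c(-c3ccc(O)cc3)coc2c1`: a limit only, > 9000 nM

Compound 3 thus stands at the edge of what this assay reports, a limit at which one of the three values sits (the limit of > 9000 nM in this assay, at which 1 of the 3 values shown sits). Compound 4 `O=C(O)CCCCCCCOc1ccc2c(=O)c(-c3ccc(O)cc3)coc2c1` differs from it by 3-carboxypropyl in place of ethoxycarbonyl on a saturated chain carbon, four bonds along the chain from an oxygen on an aromatic ring. Going by the values given here, two measured steps bear on this change, both pointing the other way: an at least 1.8-fold higher number from compound 1 to compound 3 (0.25 log units; that floor lies within the scatter) and an at least 1.6-fold higher number from compound 2 to compound 3 (0.22 log units; that floor lies within the scatter). Each floor lies within the scatter, so the evidence is weak, but both an acid end and a longer chain go with lower numbers. Compound 4 is therefore expected to move below the limit, by an at least 2.2-fold lower number from compound 3 to compound 4 (0.35 log units; beyond the scatter). Compound 4 is estimated at 4000 nM, range 1500 nM to 12000 nM.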

Compound 4, half-maximal inhibitory concentration: 6500 nM
Beside the measured number, compound 4's estimate is 1.6-fold (0.21 log units) below it; the range from low to high includes it.
By their numbers in this assay, from the lowest: compounds 1, 2 and 4 (each within the scatter of the next). At a limit, above all of these: compound 3.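

In this assay, chain length at the acid end shows no separation so far: a 1.3-fold higher number from compound 1 to compound 4 (0.11 log units; within the scatter). Acid and ester ends also stay together at this position: a 1.2-fold higher number from compound 2 to compound 4 (0.09 log units; within the scatter). Compound 3 is held at a limit and not a number, so its comparison with compound 4 gives only a floor, and the 6-carboxyhexyl end is not shown to differ from the 3-(ethoxycarbonyl)propyl end: an at least 1.3-fold lower number from compound 3 to compound 4 (0.14 log units; that floor lies within the scatter).

Open: whether an amine or an amide at the chain end, or a chain shorter than that of compound 1, would give a step beyond the scatter.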